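A few compounds are considered here, and "the series" means these few. Any claim that something is new, unique, unknown or untested is made for them only; others in the source may bear on it.

Measured compounds in a functional assay on CHO-K1 cells for antagonist activity at transient receptor potential cation channel subfamily V member 1 (Homo sapiens), read by FLIPR; on this read-out higher numbers stand for weaker inhibition and lower numbers for stronger inhibition:
- compound 1 `CC(C(=O)NCc1ccc(C(F)(F)F)nc1)c1ccc(NS(C)(=O)=O)c(F)c1`: "not active" (no number reported)
- compound 2 `Cc1ccc(Cl)cc1Nc1nc(C(F)(F)F)ccc1CNC(=O)C(C)c1ccc(NS(C)(=O)=O)c(F)c1`: 140 nM

Among the compounds with values here, compound 1 is the unsubstituted parent of the pair: in this assay compound 1 gives "not active" (no number reported), so no number places it anywhere on the scale, and no step between it and compound 2 can be counted. Within the data shown here, compound 2 carries an arylamino group on the shared core and in this assay compound 2 gives 140 nM; that is the only number in hand.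

Compound 3 `CC(C(=O)NCc1ccc(C(F)(F)F)nc1NCc1cccnc1)c1ccc(NS(C)(=O)=O)c(F)c1` is the next compound to be measured. It differs from compound 1 by ((pyridin-3-yl)methyl)amino in place of hydrogen on an aromatic carbon. The change puts a substituent at the same kind of position that is occupied in compound 2, though with a smaller group carrying a second ring nitrogen.

Among the measured compounds shown here, no measured step covers this change, so the expectation rests on comparison only. For the measured compounds named here, compound 1 is inactive and compound 2, the one substituted analogue, is active; compound 3 is therefore expected to move well beyond the scatter toward inhibition, but to remain weaker than compound 2. For compound 3 in this assay the estimate is 1500 nM, with a range from 300 nM to 8000 nM.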

Compound 3, half-maximal inhibitory concentration: "not active" (no number reported)
Compound 3 has no reported number here, so the estimate cannot be set against anything.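

In this assay, within the data shown here, compound 3 gives "not active" (no number reported) and compound 1 gives "not active" (no number reported) and no step between compound 1 and compound 3 can be read. No evidence in hand bears on this result. Left open is how far, if at all, ((pyridin-3-yl)methyl)amino in place of hydrogen alters inhibition; neither compound carries a number.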